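A second chloro in a series held at the limit

A few compounds are considered here, and "the series" means these few. Any claim that something is new, unique, unknown or untested is made for them only; others in the source may bear on it.

Measured so far in a functional assay on PC-3 cells (Homo sapiens) for inhibition, read by MTT assay, with a stated time of 24 h; a lower number here means a stronger inhibitor, a higher number a weaker inhibitor:
Compound 1 `O=C(Cn1c(=O)c(/C=C\c2ccncc2)nc2ccccc21)Nc1ccccc1`: > 100000 nM, a limit
Compound 2 `O=C(Cn1c(=O)c(/C=C\c2ccncc2)nc2ccccc21)Nc1ccc(Cl)cc1`: > 100000 nM, a limit
Compound 3 `Cc1ccccc1NC(=O)Cn1c(=O)c(/C=C\c2ccncc2)nc2ccccc21`: > 100000 nM, a limit

Compound 2 has only a limit, > 100000 nM, and no number. The series as a whole gives the same picture: the limit of > 100000 nM in this assay, at which 3 of the 3 values shown sit.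

Compound 4 `O=C(Cn1c(=O)c(/C=C\c2ccncc2)nc2ccccc21)Nc1ccc(Cl)c(Cl)c1` differs from compound 2 as follows: chloro in place of hydrogen on an aromatic carbon. Cut one bond further out, this is 4-chlorophenyl to 3,4-dichlorophenyl.

Among the measured compounds shown here, the closest precedent is a step that the two limits leave unreadable from compound 1 to compound 2, which is also chloro in place of hydrogen on an aromatic carbon. The other two are a step that the two limits leave unreadable from compound 1 to compound 3 and a step that the two limits leave unreadable from compound 2 to compound 3. None of the three gives a size or a direction. With only these to go on, no step beyond the scatter is expected, and compound 4 is expected to stay at the limit.

If a number is reported, compound 4 is expected near 100000 nM, with an estimated range from 30000 nM to 200000 nM. The estimate means a number no higher from compound 2 to compound 4 (the limit leaves the size open), which is expected to be no real change.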

Compound 4, half-maximal inhibitory concentration: > 100000 nM
Compound 4: no number, only a limit; the forecaster's own chance of this, stated with the estimate: 75%; the middle value lies on the limit itself.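

In this assay, among the compounds shown here, compound 4 gives > 100000 nM, a limit and not a number, so no step to compound 4 from compound 1, compound 2 or compound 3 can be read. The compounds shown leave open the size and direction of any effect of these aryl changes, with the whole series in one place: the limit of > 100000 nM in this assay, at which 4 of the 4 values shown sit.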